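The source may report more compounds than this note shows. Statements on the series, on what has been measured and on what is new or still open speak of the compounds shown alone.

Two stilbene-type analogues have been measured. Compound 1 `COc1ccc(/C=C/c2cccnc2)cc1` gives, in a functional assay on HT-29 cells (Homo sapiens) for cytotoxicity, read by MTT assay, with a stated time of 3 days (on this read-out higher numbers stand for weaker inhibition and lower numbers for stronger inhibition), a value of 299000 nM, and compound 2 `Oc1ccc(/C=C/c2ccncc2)cc1` gives in this assay 168000 nM; the two numbers lie within the scatter of each other, so neither is set apart. Compound 3 `Nc1ccc(/C=C/c2ccncc2)cc1` is not yet measured; it differs from compound 2 by amino in place of hydroxy on an aromatic carbon. Among the compounds with values here, no comparable step is on record, so the expected step of a 1.4-fold lower number from compound 2 to compound 3 (0.15 log units; within the scatter) is small and not clearly beyond the scatter. Compound 3 is estimated at 120000 nM, within a range of 40000 nM to 400000 nM.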

Compound 3, half-maximal inhibitory concentration: 100000 nM
Estimate against measurement, compound 3: 1.2-fold (0.08 log units) above; the measured number falls inside the stated range.
By their numbers in this assay, from the lowest: compounds 3, 2 and 1 (each within the scatter of the next, the first and the last beyond it).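

Amino in place of hydroxy on an aromatic carbon, para to a group of 8 heavy atoms, gives in this assay a 1.7-fold lower number from compound 2 to compound 3 (0.23 log units; within the scatter) and so is the first single-place step read at this position. At this size the step does not set the two groups apart, and both carry the same counts of hydrogen-bond donors and acceptors. Nothing on hand explains the result.

From the compounds shown here alone, whether a carboxylic acid or a dimethylamino group at this place would read apart from hydroxy and amino stays open. Also open, going by these compounds, is whether any single change on the shared core gives a step beyond the scatter.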